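The compounds below may be only part of what the source reports. "The series", "measured", "known", "first", "only" and "open" are said of these compounds alone.

Measured in a functional assay on DU-145 cells (Homo sapiens) for cytotoxicity, read by MTT assay; on this read-out lower numbers stand for stronger inhibition and higher numbers for weaker inhibition:
- compound 1 `CCC(O)CO[C@H](CC=C(C)C)C1=CC(=O)c2c(O)ccc(O)c2C1=O`: 16400 nM
- compound 2 `CC(C)=CC[C@@H](OCC(C)O)C1=CC(=O)c2c(O)ccc(O)c2C1=O`: 16100 nM
- compound 3 `CC(C)=CC[C@@H](OC(=O)C1CCOC1)C1=CC(=O)c2c(O)ccc(O)c2C1=O`: not yet measured

Among the compounds with values here, compound 2 stands level with the only other measured compound in this assay. Within the data shown here, the single measured step, a 1.0-fold lower number from compound 1 to compound 2 (0.01 log units; within the scatter), exchanges only a methyl on the chain, so it bears weakly on the change now made: (oxolan-3-yl)carbonyl in place of 2-hydroxypropyl on an oxygen on a saturated carbon. Among the measured compounds shown here, no measured compound carries the entering group, so the direction rests on little. A moderate move to a lower number is expected, with wide uncertainty. The expected step is a 2.0-fold lower number from compound 2 to compound 3 (0.30 log units; within the scatter). Compound 3 is estimated at 8000 nM, with an expected range of 2000 nM to 25000 nM.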

Compound 3, half-maximal inhibitory concentration: 47500 nM
Beside the measured number, compound 3's estimate is 5.9-fold (0.77 log units) below it, and the stated range ends below it.
By their numbers in this assay, from the lowest: compounds 2 and 1 (each within the scatter of the next); then compound 3.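

In this assay, the oxygen on a saturated carbon responds to a larger change of group: (oxolan-3-yl)carbonyl gives a 3.0-fold higher number from compound 2 to compound 3 (0.47 log units; beyond the scatter) and a 2.9-fold higher number from compound 1 to compound 3 (0.46 log units; beyond the scatter), whereas the methyl exchange on the chain stayed within the scatter. This change alters the ring, donor and acceptor counts together, and these steps do not separate them. No supporting data bear on the origin of this shift.

Open, on these data alone, is how an acetyl group, with no ring, would read on this oxygen. Also open, as far as these compounds go, is how a chain carrying an amine would read there.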